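The compounds below may be only part of what the source reports. "The series", "measured", "known", "first", "only" and "open" are said of these compounds alone.

Of the compounds shown here, three have been measured in a functional assay, with a stated time of 30 min; on this read-out higher numbers stand for weaker inhibition and lower numbers for stronger inhibition. Compound 1 `CO[C@]1(CO)O[C@H](CO)[C@@H](O)[C@@H]1O` gives > 30000 nM in this assay, a limit of the measurement rather than a number. Compound 2 `CO[C@@]1(CO)O[C@H](CO)[C@@H](O)[C@@H]1O` gives > 30000 nM, again a limit. These two have the same atoms and bonds and differ only in configuration as drawn, so the step that the two limits leave unreadable from compound 1 to compound 2 cannot be read. Compound 3 `COC(=O)C1=CO[C@@H](O[C@@H]2O[C@H](CO)[C@@H](O)[C@H](O)[C@H]2O)C2C1[C@@H]1O[C@@H]1[C@]21O[C@@H]1O`, the starting point here, gives > 30000 nM, once more a limit. On the numbers shown compound 3 thus stands at the limit together with the other two, with nothing to rank it against them.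

Compound 4 `COC(=O)C1=CO[C@@H](O[C@@H]2O[C@H](CO)[C@@H](O)[C@H](O)[C@H]2O)C2C1[C@@H]1O[C@@H]1[C@]21O[C@H]1O` has not been measured. Its relation to compound 3 is the two compounds have the same atoms and bonds; at least one stereo element is drawn with a configuration in one of them and without one in the other: 1 of 12 stereo elements differ; a stereocentre at a saturated ring carbon is drawn S in compound 3 and R in compound 4. Within the data shown here, the only measured step of the same kind is the one between the first two compounds, and its size is unreadable because the limit of > 30000 nM in this assay, at which 3 of the 3 values shown sit, hides both ends; that pair is the closest analogue because the fact that compounds 1 and 2 differ only in the configuration as drawn matches the present change. Nothing measured points to a shift in either direction.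

The expected step is a step that the limit leaves unreadable from compound 3 to compound 4, nothing beyond the scatter. Compound 4 is estimated to remain at the limit, around 40000 nM, with a range from 10000 nM to 150000 nM.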

Compound 4, half-maximal inhibitory concentration: > 30000 nM
Compound 4 gave a limit, no number (the forecaster's own chance of this, stated with the estimate: 85%); the middle value is on the limit's open side.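

In this assay compound 4 gives > 30000 nM, a limit rather than a number. Among these compounds, no new step can therefore be read between compound 3 and compound 4: the limit of > 30000 nM in this assay, at which 4 of the 4 values shown sit. The compounds shown leave open whether the configuration at this stereocentre changes inhibition at all, and how far any of them lies past the limit.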